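Methanesulfonamido replacing hydroxy on the side chain

The compounds below may be only part of what the source reports. "The series", "measured", "known", "first", "only" and "open" are said of these compounds alone.

Two compounds of this series carry a number in an assay on cells for agonist activity at Bombesin receptor subtype-3 (Homo sapiens), read by HTRF and inositol phosphate accumulation, with a stated time of 1 h; on this read-out lower numbers stand for an effect already at smaller amounts and higher numbers for an effect only at larger amounts of compound. Compound 1 `COC(=O)c1c(F)cccc1-c1ccc(CCc2ncc(CC(C)(C)C)n2CCNS(C)(=O)=O)cc1` gives 11 nM; compound 2 `CC(C)(C)Cc1cnc(CCc2ccc(-c3cccc(F)c3C(=O)O)cc2)n1CCO` gives 3 nM, the lowest of the two, with compound 1 standing above it by a gap beyond the usual scatter. Within the data shown here, compound 1 and compound 2 differ in more than one place, so no single step between measured compounds is drawn from them; their two values show only that the pair lies apart.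

Compound 3 `CC(C)(C)Cc1cnc(CCc2ccc(-c3cccc(F)c3C(=O)O)cc2)n1CCNS(C)(=O)=O` has not yet been measured in this assay. From compound 2 it differs by methanesulfonamido in place of hydroxy on a saturated chain carbon, two bonds along the chain from an aromatic nitrogen. Compound 1 carries the same methanesulfonamido chain and sits higher than compound 2, but with the second difference inside that pair the share of the chain in the gap cannot be separated. The change is expected to move the number little, a step of a 1.5-fold higher number from compound 2 to compound 3 (0.18 log units; within the scatter) that stays near the scatter or turns slightly upward. For compound 3 the estimate in this assay is 4.5 nM, with a range from 1.5 nM to 13 nM.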

Compound 3, half-maximal effective concentration: 2 nM
For compound 3 the middle estimate is 2.3-fold (0.35 log units) above the measured one, within the range that was stated.
By their numbers in this assay, from the lowest: compounds 3 and 2 (each within the scatter of the next); then compound 1.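

Working notes on the side chain: in this assay, the position on a saturated chain carbon, two bonds along the chain from an aromatic nitrogen, accepts methanesulfonamido (5 heavy atoms) in place of hydroxy (1 heavy atom) with no step beyond the scatter (a 1.5-fold lower number from compound 2 to compound 3 (0.18 log units; within the scatter)). With the 2-(methanesulfonamido)ethyl chain now common to both compounds, the pair of compound 1 and compound 3 differs in one place only, and hydrogen in place of methyl on an oxygen next to a carbonyl group reads as a step beyond the scatter (a 5.5-fold lower number from compound 1 to compound 3 (0.74 log units; beyond the scatter)). Nothing available explains the size of either step.

The compounds shown leave open whether the tolerance at this position extends to other replacements for hydroxy, such as a primary amine, an acetamido group or a longer chain ending in methanesulfonamido. Going by these compounds, it also remains open whether hydrogen in place of methyl on that oxygen gives a step of similar size when the side chain carries hydroxy, since the step is read here only with methanesulfonamido on the chain.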